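A few compounds are considered here, and "the series" means these few. Any claim that something is new, unique, unknown or untested is made for them only; others in the source may bear on it.

Of the compounds shown here, three built on one shared core have been tested in a functional assay on A549 cells (Homo sapiens) for inhibition, read by MTT assay, with a stated time of 72 h; on this read-out lower numbers stand for stronger inhibition and higher numbers for weaker inhibition. Compound 1 `CN(C(=O)NC(=O)c1ccccc1F)c1nc(C(F)(F)F)c(C(=O)N/N=C/c2ccc(C(F)(F)F)cc2)s1` gives 5.68 ug/mL. Compound 2 `CN(C(=O)NC(=O)c1cccc(C(F)(F)F)c1)c1nc(C(F)(F)F)c(C(=O)N/N=C/c2ccccc2C(F)(F)F)s1` gives 12.1 ug/mL in this assay, and compound 3 `CN(C(=O)NC(=O)c1cccc([N+](=O)[O-])c1)c1nc(C(F)(F)F)c(C(=O)N/N=C/c2ccccc2C(F)(F)F)s1` gives 5.45 ug/mL. Compound 3 thus stands at the lowest of the three numbers, though its gap to compound 1 is within the scatter; only compound 2 lies beyond it, as the step of a 2.2-fold lower number from compound 2 to compound 3 (0.35 log units; beyond the scatter) shows.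

The step now followed leads to compound 4 `CN(C(=O)NC(=O)c1ccc(F)c(F)c1)c1nc(C(F)(F)F)c(C(=O)N/N=C/c2ccccc2C(F)(F)F)s1`, which has not yet been measured in this assay. The change is 3,4-difluorophenyl in place of 3-nitrophenyl on a carbonyl carbon. Within the data shown here, one measured step bears on it: a 2.2-fold lower number from compound 2 to compound 3 (0.35 log units; beyond the scatter), where nitro in place of trifluoromethyl on an aromatic carbon went with a modestly lower number. Compound 4 removes the nitro again, though what enters is 3,4-difluorophenyl rather than a trifluoromethyl-bearing ring, so the plain reading is a modest rise. Against that, compound 1, which also carries a fluorinated phenyl on a carbonyl carbon but a different hydrazone, shows a number within the scatter of compound 3, so the rise may well be small or absent.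

On balance compound 4 is expected to show a step of a 1.6-fold higher number from compound 3 to compound 4 (0.19 log units; within the scatter) in this assay. Compound 4 is therefore estimated at 8.5 ug/mL, with a range from 4 ug/mL to 18 ug/mL.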

Compound 4, half-maximal inhibitory concentration: 6.96 ug/mL
Compound 4: middle estimate off by 1.2-fold (0.09 log units), on the high side, within the range that was stated.
By their numbers in this assay, from the lowest: compounds 3, 1, 4 and 2 (each within the scatter of the next, the first and the last beyond it).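

On the carbonyl carbon whose other neighbour is the amide-type nitrogen, with the rest of the molecule unchanged, this assay gives a 1.3-fold higher number from compound 3 to compound 4 (0.11 log units; within the scatter), so 3,4-difluorophenyl and 3-nitrophenyl cannot be told apart here, and a ring without the nitro need not give up what the earlier nitro step showed. The second step, a 1.7-fold lower number from compound 2 to compound 4 (0.24 log units; within the scatter), also stays within the scatter, which places compound 4 within reach of both compound 2 and compound 3, although those two lie beyond the scatter of each other, so the three groups at this place span only a narrow band of numbers. Nothing measured here accounts for these numbers.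

Every ring at this place in the compounds shown carries fluorine or a nitro, so it remains open whether an unsubstituted phenyl, a ring bearing a methoxy group or an amine, or a saturated ring such as cyclohexyl would stay within the same band. From the compounds shown here alone, it is also open whether 3,4-difluorophenyl would read the same with another hydrazone, since compound 1 differs from compound 4 in more than one place.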